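A thiophene in place of phenyl on a short-lived compound

The compounds below may be only part of what the source reports. "The series", "measured", "known", "first", "only" and "open" are said of these compounds alone.

In an ADME assay on microsomes (Rattus norvegicus) for metabolic stability, using NADPH (on this read-out lower numbers stand for a shorter-lived compound and higher numbers for a longer-lived compound), compound 1 `COc1cc(C(=O)N(C/C=C/c2ccccc2)Cc2ccc(CC(=O)O)cc2)cc(OC)c1C` gives > 3.33 h, which is a limit and not a number. Compound 2 `COc1cc([C@@H](O)[C@@H](CCCc2ccccc2)Cn2ccc(CC(=O)O)c2)cc(OC)c1C` gives < 0.25 h, also a limit. Compound 3 `COc1cc([C@@H](O)[C@@H](CCCc2ccsc2)Cn2ccc(CCC(=O)O)c2)cc(OC)c1C` gives < 0.25 h, again a limit. Compound 2 therefore stands at the limit of < 0.25 h in this assay, at which 2 of the 3 values shown sit, the short-lived end of the values shown, and has no exact number. Compound 4 `COc1cc([C@@H](O)[C@@H](CCCc2cccs2)Cn2ccc(CC(=O)O)c2)cc(OC)c1C` differs from compound 2 by one change: thiophen-2-yl in place of phenyl on a saturated chain carbon, five bonds along the chain from an aromatic carbon, an aromatic nitrogen and an oxygen on a saturated carbon. Here 3-(thiophen-2-yl)propyl takes the place of 3-phenylpropyl. Going by the values given here, no measured pair shows this change. The estimated step that the limit leaves unreadable from compound 2 to compound 4 is expected to stay within the scatter, in neither direction. In this assay compound 4 is expected at 0.2 h, with an estimated range from 0.1 h to 0.4 h.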

Compound 4, half-life: < 0.25 h
Compound 4: no number, only a limit; the forecaster's own chance of this, stated with the estimate: 80%; the middle value lies beyond the limit too.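

In this assay, going by these compounds alone, compound 2 and compound 4 both rest on a limit and not a number, so no step between them can be read. Going by these compounds, whether thiophen-2-yl in place of phenyl shifts the half-life at all stays open.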